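Hydroxy to Dimethylamino: Expecting Another Limit

The source may hold more compounds than are shown below. What is called first, only, known or untested is meant among the compounds shown, and "the series" means these compounds.

Of the compounds shown here, two have been measured so far. Compound 1 `O=c1[nH]c(=O)n(COCCO)cc1[N+](=O)[O-]` carries a nitro group on its core. In a functional assay (Oryctolagus cuniculus) for inhibition (on this read-out higher numbers stand for weaker inhibition and lower numbers for stronger inhibition), compound 1 gives > 400 ug/mL, which is a limit of the assay and not a number. Compound 2 `OCCOCn1cnc2c(O)ncnc21` gives in this assay > 100 ug/mL, again only a limit. Compound 2 therefore stands among limits alone, with no numbered value anywhere in the set. Compound 3 `CN(C)c1ncnc2c1ncn2COCCO` differs from compound 2 by dimethylamino in place of hydroxy on an aromatic carbon. Because the shown values are limits, the limit of > 100 ug/mL in this assay, at which 1 of the 2 values shown sits, and (the limit of > 400 ug/mL in this assay, at which 1 of the 2 values shown sits), no measured step can guide the size of the change. Compound 3 is expected to show no change beyond the scatter, a step that the limit leaves unreadable from compound 2 to compound 3. Compound 3 is estimated at 150 ug/mL, ranging from 50 ug/mL to 500 ug/mL.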

Compound 3, concentration for 50% inhibition: 400 ug/mL
Estimate against measurement, compound 3: 2.7-fold (0.43 log units) below; the measured number falls inside the stated range.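

Among the compounds shown here, compound 3 gives a number, but no step from compound 2 to compound 3 can be read, because compound 2 has only a limit: the limit of > 100 ug/mL in this assay, at which 1 of the 3 values shown sits.

The compounds shown leave open whether dimethylamino in place of hydroxy on an aromatic carbon changes inhibition at all.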